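The source may hold more compounds than are shown below. What is called first, only, known or untested is meant among the compounds shown, and "the series" means these compounds.

Compound 1 `CCCCc1cn(C(c2ccccc2)c2cc3cc(Br)ccc3nc2OC)nn1`: 5.54%
Compound 2 `CCCCCCc1cn(C(c2ccccc2)c2cc3cc(Br)ccc3nc2OC)nn1`: 2.32%
Compound 3 `COc1nc2ccc(Br)cc2cc1C(c1ccccc1)n1cc(CCO)nn1`: 15.5%

All three were tested in an ADME assay on PC-3 cells (Homo sapiens) for cytotoxicity, read by sulforhodamine B assay, with a stated time of 48 h, tested at 10 uM; a higher number here means more inhibition at the concentration tested (going by the name of the read-out), a lower number less inhibition. Among the compounds with values here, compound 3 gives the highest of the three numbers, yet its gap to compound 1 stays within the scatter; only the step of a number 13.2 percentage points higher from compound 2 to compound 3 (beyond the scatter) goes beyond it. Compound 4 `COc1nc2ccc(Br)cc2cc1C(c1ccccc1)n1cc(-c2ccccc2)nn1` differs from compound 3 by phenyl in place of 2-hydroxyethyl on an aromatic carbon. Within the data shown here, no measured step exchanges a chain for a ring. The nearest guides are a number 10 percentage points higher from compound 1 to compound 3 (within the scatter) and a number 13.2 percentage points higher from compound 2 to compound 3 (beyond the scatter), where hydroxy took the place of ethyl or butyl and the number rose. As far as these compounds go, compound 4 removes the hydroxy-bearing chain again, so a small drop is expected, a number 9.5 percentage points lower from compound 3 to compound 4 (within the scatter), though the new group is untested here. Compound 4 is therefore estimated at 6%, between 0% and 18%.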

Compound 4, a percentage reported as inhibition, at one concentration (the size of the read-out at that concentration, not a potency): 5.97%
Estimate against measurement, compound 4: 0 percentage points above; the range from low to high includes it.
By their numbers in this assay, from the lowest: compounds 2, 1, 4 and 3 (each within the scatter of the next, the first and the last beyond it).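

Phenyl is the first ring on this carbon of the five-membered ring, and in this assay it gives a number 0.4 percentage points higher from compound 1 to compound 4 (within the scatter) and a number 3.7 percentage points higher from compound 2 to compound 4 (within the scatter) when it replaces butyl and hexyl. Replacing 2-hydroxyethyl gives a number 9.5 percentage points lower from compound 3 to compound 4 (within the scatter) and so, with all three steps within the scatter, this ring cannot be told apart from any of the three chains. Nothing given here explains these numbers. As far as these compounds go, whether a carboxylic acid, an aminomethyl group or a pyridine ring at this carbon would move the number beyond the scatter stays open.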